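Swapping a ring on the core: from oxolanyl to difluorocyclobutyl

This account rests on a few compounds, and the source may have more. Where it says the series, first, only, none or still open, it means among the compounds named here.

Measured compounds:
compound 1, `COc1ccc(-n2c(C)nc3c(NC(C4CC4)C4CC4)nc(C)nc32)cc1`, 19 nM
compound 2, `COc1ccc(-n2c(CC3CC3)nc3c(NC(C4CC4)C4CC4)nc(C)nc32)cc1`, 308 nM
compound 3, `COc1ccc(-n2c(C3CCCO3)nc3c(NC(C4CC4)C4CC4)nc(C)nc32)cc1`, 867 nM

All three were tested in a functional assay on CHO cells for antagonist activity at corticotropin-releasing factor receptor 1 (Homo sapiens), read by cAMP accumulation; on this read-out higher numbers stand for weaker inhibition and lower numbers for stronger inhibition. Among them compound 3 has the highest number, standing a 2.8-fold higher number from compound 2 to compound 3 (0.45 log units; beyond the scatter) and a 46-fold higher number from compound 1 to compound 3 (1.66 log units; beyond the scatter). Both steps reach compound 3 by placing a bigger group on the same aromatic carbon of the shared core, and both raise the number beyond the scatter, the larger one when the starting group is the small methyl of compound 1.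

Compound 4, `COc1ccc(-n2c(C3CC(F)(F)C3)nc3c(NC(C4CC4)C4CC4)nc(C)nc32)cc1`, continues along this line: 3,3-difluorocyclobutyl in place of oxolan-2-yl on an aromatic carbon. Here one ring gives way to another ring of similar bulk, so the outcome should sit closer to compound 3 than to compound 1. Since the ring-for-ring step from compound 2 to compound 3 was only modest, a change of comparable size is expected, most likely toward a somewhat lower number, giving a 1.7-fold lower number from compound 3 to compound 4 (0.24 log units; within the scatter). Compound 4 is therefore estimated at 500 nM, with a plausible range from 120 nM to 2000 nM.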

Compound 4, inhibition constant: 261 nM
The estimate for compound 4 lay 1.9-fold (0.28 log units) above the measured number; the measured number falls inside the stated range.
By their numbers in this assay, from the lowest: compound 1; then compounds 4 and 2 (each within the scatter of the next); then compound 3.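

In this assay, the step of a 3.3-fold lower number from compound 3 to compound 4 (0.52 log units; beyond the scatter) shows that at this position the outcome depends on which ring is present, and not simply on there being a ring. Yet the new ring offers no clear separation from the cyclopropylmethyl group, with a 1.2-fold lower number from compound 2 to compound 4 (0.07 log units; within the scatter) here, and the methyl group keeps a wide lead, with a 14-fold higher number from compound 1 to compound 4 (1.14 log units; beyond the scatter) in this comparison. The swap removes the ring oxygen and adds two fluorine atoms, but no measurement here tells which of these changes matters, or why the two rings differ.

The compounds shown leave open how plain cyclobutyl, which has neither oxygen nor fluorine, would compare with these two rings. They also leave open whether a small group other than methyl, such as ethyl, would keep the number near that of compound 1.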